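A chlorine moved around the phenyl ring

A few compounds are considered here, and "the series" means these few. Any claim that something is new, unique, unknown or untested is made for them only; others in the source may bear on it.

Three compounds have been measured so far:
compound 1 `O=C1CSC(c2cccc(F)c2)N1CCN1CCCCC1` gives 97%
compound 2 `O=C1CSC(c2ccccc2Cl)N1CCN1CCCCC1` gives 100%
compound 3 `COc1ccccc1C1SCC(=O)N1CCN1CCCCC1` gives 100%

All three numbers come from an ADME assay on Vero cells (Chlorocebus sabaeus) for cytotoxicity, read by neutral red uptake, tested at 49 ug/mL; on this read-out lower numbers stand for a stronger effect and higher numbers for a weaker effect at the one concentration tested. Compound 2 stands level with compound 3 at the digits printed, and together they are the highest of the three numbers, with compound 1 furthest away. The step of a number 3 percentage points higher from compound 1 to compound 2 (within the scatter) exchanged one aryl group for another on the saturated ring carbon, and the step of no change at the digits printed from compound 2 to compound 3 (within the scatter) exchanged chloro for methoxy on the aromatic carbon; neither moved the read-out beyond the usual scatter.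

Compound 4 `O=C1CSC(c2cccc(Cl)c2)N1CCN1CCCCC1` is the next compound to test. It differs from compound 2 as follows: 3-chlorophenyl in place of 2-chlorophenyl on a saturated ring carbon. Both measured steps bear on this change, since each altered the same aryl group at the same place, and both stayed within the scatter. The expected step is therefore none beyond the scatter, a number 2 percentage points lower from compound 2 to compound 4 (within the scatter). For compound 4 the estimated value in this assay is 98%, expected to fall between 88% and 105%.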

Compound 4, a percentage reported as activity, at one concentration (the size of the read-out at that concentration, not a potency): 100%
For compound 4 the middle estimate is 2 percentage points below the measured one, within the range that was stated.
By their numbers in this assay, from the lowest: compounds 1, 2, 3 and 4 (each within the scatter of the next).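

In this assay, 3-chlorophenyl in place of 2-chlorophenyl on the saturated ring carbon gives no change at the digits printed from compound 2 to compound 4 (within the scatter) and so, for this pair, the place of the chlorine on the phenyl ring makes no difference beyond the scatter. Chloro in place of fluoro on an aromatic carbon gives a number 3 percentage points higher from compound 1 to compound 4 (within the scatter) and this is the first comparison in which the halogen alone differs. The earlier step between compound 1 and compound 2 changed the halogen and its place together, whereas compound 4 allows each change to be read alone, and neither goes beyond the scatter.

On these data alone, whether an amine or a carboxylic acid on the phenyl ring would also leave the read-out within the scatter remains open. Nothing available here explains why these changes leave the read-out within the scatter.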